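The source may report more compounds than this note shows. Statements on the series, on what has been measured and on what is new or still open speak of the compounds shown alone.

Measured in a functional assay on MV4-11 cells (Homo sapiens) for antiproliferative activity, with a stated time of 6 days, tested at 1.56 uM; on this read-out lower numbers stand for a weaker effect and higher numbers for a stronger effect at the one concentration tested:
Compound 1, `CNC(=O)N1CCCc2ccc(NC(=O)c3cccc(-c4ccn(C(C)=O)n4)c3)cc21`: 27.6%
Compound 2, `CNC(=O)N1CCCc2ccc(NC(=O)c3cccc(-c4cnn(S(C)(=O)=O)c4)c3)cc21`: 1.6%
Compound 3, `CNC(=O)N1CCCc2ccc(NC(=O)c3cccc(-c4cnn(C)c4)c3)cc21`: 71.2%

Compound 3 stands highest of the three numbers in this assay. Compound 1 is the nearer of the other two, the step being a number 43.6 percentage points higher from compound 1 to compound 3 (beyond the scatter); compound 2 is the furthest, with a number 69.6 percentage points higher from compound 2 to compound 3 (beyond the scatter).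

Compound 4, `CNC(=O)N1CCCc2ccc(NC(=O)c3cccc(-c4cn[nH]c4)c3)cc21`, differs from compound 3 by hydrogen in place of methyl on an aromatic nitrogen. The step that bears most directly is a number 69.6 percentage points higher from compound 2 to compound 3 (beyond the scatter), since it alters the group on the same aromatic nitrogen and was large. The steps of a number 26 percentage points lower from compound 1 to compound 2 (beyond the scatter) and a number 43.6 percentage points higher from compound 1 to compound 3 (beyond the scatter) also pass through this part of the series, but each changes the attachment of the ring at the same time, so they speak less cleanly. For the measured compounds named here, no measured step removes a group from that nitrogen to leave a hydrogen, so the direction is not fixed by the data; the large swing from compound 2 to compound 3 shows only that this position is sensitive. A moderate fall below compound 3 is taken as the working expectation, with wide uncertainty, so compound 4 is expected to give 55% (range 25% to 85%), i.e. an estimated a number 16.2 percentage points lower from compound 3 to compound 4 (beyond the scatter).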

Compound 4, a percentage reported as inhibition, at one concentration (the size of the read-out at that concentration, not a potency): 27.9%
Compound 4: middle estimate off by 27.1 percentage points, on the high side; measured number inside the range.
By their numbers in this assay, from the lowest: compound 2; then compounds 1 and 4 (each within the scatter of the next); then compound 3.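

In this assay, this aromatic nitrogen can now be read with three different substituents on the same 1H-pyrazol-4-yl group, and a number 43.3 percentage points lower from compound 3 to compound 4 (beyond the scatter) shows that the methyl matters in its own right, since the high number of compound 3 is not kept once hydrogen takes its place. With a number 26.3 percentage points higher from compound 2 to compound 4 (beyond the scatter) as well, the order at this nitrogen is methyl, then hydrogen, then methylsulfonyl, each step beyond the scatter. With a number 0.3 percentage points higher from compound 1 to compound 4 (within the scatter), the 1H-pyrazol-4-yl and 1-acetyl-1H-pyrazol-3-yl groups cannot be told apart on this read-out, and nothing available explains any of these differences.

Open, on these data alone, is whether ethyl, a longer chain or a chain ending in an amine on this nitrogen would match or pass compound 3 at 71.2%. As far as these compounds go, each number is also a single-concentration effect, so potency remains open.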